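The source may hold more compounds than are shown below. What is called first, only, known or untested is meant among the compounds shown, and "the series" means these compounds.

Measured in a functional assay on RS4-11 cells (Homo sapiens) for inhibition, read by CCK-8 assay, with a stated time of 72 h; a lower number here means a stronger inhibitor, a higher number a weaker inhibitor:
- Compound 1 `CC1(C)CCC(CN2CCN(c3ccc(C(=O)NS(=O)(=O)c4ccc(NCC5CCOCC5)c([N+](=O)[O-])c4)c(Oc4cnc5[nH]ccc5c4)c3)CC2)=C(c2ccc(Cl)cc2C(F)(F)F)C1`: 74 nM
- Compound 2 `CCN(CC)CCCNc1ccc(S(=O)(=O)NC(=O)c2ccc(N3CCN(CC4=C(c5ccc(C(F)(F)F)cc5)CC(C)(C)CC4)CC3)cc2Oc2cnc3[nH]ccc3c2)cc1[N+](=O)[O-]`: 3 nM

Of these two, compound 2 has the lower number, a gap beyond the scatter. Compound 3 `CC1(C)CCC(CN2CCN(c3ccc(C(=O)NS(=O)(=O)c4ccc(OCC5CCOC5)c([N+](=O)[O-])c4)c(Oc4cnc5[nH]ccc5c4)c3)CC2)=C(c2ccc(C(F)(F)F)cc2)C1` has (oxolan-3-yl)methoxy in place of (3-(diethylamino)propyl)amino on an aromatic carbon. Going by the values given here, no measured pair isolates this change. The closest guide is compound 1, which also lacks the diethylamino chain, though it differs elsewhere, and gives 74 nM. A weakening beyond the scatter in this assay is therefore expected, with an estimated step of a 10-fold higher number from compound 2 to compound 3 (1.00 log units; beyond the scatter). For compound 3 the estimated value is 30 nM, with an expected range of 8 nM to 120 nM.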

Compound 3, half-maximal inhibitory concentration: 47 nM
Estimate against measurement, compound 3: 1.6-fold (0.19 log units) below; the measured number falls inside the stated range.
By their numbers in this assay, from the lowest: compound 2; then compounds 3 and 1 (each within the scatter of the next).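

In this assay, going by these compounds alone, compounds 2 and 3 are the first pair that differ in one place only, on an aromatic carbon ortho to a nitro group. Putting (oxolan-3-yl)methoxy in place of (3-(diethylamino)propyl)amino there gives a 16-fold higher number from compound 2 to compound 3 (1.19 log units; beyond the scatter), so this one change is enough for a large step. No available evidence accounts for the size of this step.

From the compounds shown here alone, the swap replaces both the linking atom and the chain end, so the source of the step remains open. An (oxolan-3-yl)methylamino group would help to separate these two parts.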